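Swapping Ethoxycarbonyl for Methoxycarbonyl: What to Expect

The compounds below may be only part of what the source reports. "The series", "measured", "known", "first", "only" and "open" are said of these compounds alone.

Measured in a functional assay, read by spectrophotometry, with a stated time of 10 min; a higher number here means that more compound is needed for the effect, a lower number that less compound is needed:
- compound 1 `CCOC(=O)C1=C(C)NC(=O)NC1c1cccc([N+](=O)[O-])c1`: 1.16 ug/mL
- compound 2 `COC(=O)C1=C(C)NC(=O)NC1c1ccc(O)cc1`: 0.79 ug/mL
- compound 3 `COC(=O)C1=C(C)NC(=O)NC1c1ccc([N+](=O)[O-])cc1`: 1.71 ug/mL

Compound 1 gives 1.16 ug/mL, a number within the usual scatter of those of both other compounds. It therefore sits in the middle of a narrow set, and neither neighbour stands clearly apart from it.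

The next compound to be measured is compound 4 `COC(=O)C1=C(C)NC(=O)NC1c1cccc([N+](=O)[O-])c1`. It differs from compound 1 by a single change: hydrogen in place of methyl on a saturated chain carbon bound to an oxygen next to a carbonyl group. Put simply, this is hydrogen in place of methyl on a saturated chain carbon bound to an oxygen next to a carbonyl group, so ethoxycarbonyl becomes methoxycarbonyl.

Among the compounds with values here, no measured step makes this exact change. Within the data shown here, the only step available, a 2.2-fold higher number from compound 2 to compound 3 (0.34 log units; beyond the scatter), is modest and swaps nitro for hydroxy on an aromatic carbon, so it bears on this question only indirectly. It does show that this assay can separate compounds that carry methoxycarbonyl, as compound 2 gives 0.79 ug/mL and compound 3 gives 1.71 ug/mL.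

With no evidence for a shift in either direction, no step beyond the scatter is expected. The expected step is a 1.1-fold higher number from compound 1 to compound 4 (0.05 log units; within the scatter). For compound 4 the estimated value is 1.3 ug/mL, with an expected range from 0.7 ug/mL to 2.3 ug/mL.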

Compound 4, half-maximal effective concentration: 1.6 ug/mL
For compound 4 the middle estimate is 1.2-fold (0.09 log units) below the measured one; the range from low to high includes it.
By their numbers in this assay, from the lowest: compounds 2, 1, 4 and 3 (each within the scatter of the next, the first and the last beyond it).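

Within the data shown here, this pair is the first direct test of the ester end of the molecule, since the earlier compounds all differed on the aromatic ring or in more than one place. In this assay, going from ethoxycarbonyl to methoxycarbonyl brings a 1.4-fold higher number from compound 1 to compound 4 (0.14 log units; within the scatter) and so leaves the two numbers indistinguishable, which means that the methyl lost from the saturated chain carbon bound to an oxygen next to a carbonyl group makes no measurable difference in this single pair. Nothing available explains this outcome or ties it to any measured property of the two groups.

From the compounds shown here alone, the result covers only ethoxycarbonyl and methoxycarbonyl on the core of compound 1, so it remains open whether a longer chain such as propoxycarbonyl or butoxycarbonyl, a carboxylic acid, or an amide in the same place would also stay within the scatter or would shift the number clearly. Going by these compounds, it also remains open whether the same swap would give as small a step on a core carrying the hydroxy group of compound 2 instead of a nitro group.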